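A few compounds are considered here, and "the series" means these few. Any claim that something is new, unique, unknown or untested is made for them only; others in the source may bear on it.

Measured so far in an ADME assay on microsomes from liver (Mus musculus) for metabolic stability, read by LC-MS, using NADPH, with stated times of 10 min and 30 min, tested at 1 uM; a higher number here means faster removal of the compound, a lower number slower removal:

- compound 1, `COC(=O)C1=C(CN2CCCCC2)NC(c2nccs2)=NC1(C)c1ccc(F)cc1`, gives 88 mL/min/kg
- compound 2, `COC(=O)C1=C(CN2CCNCC2)NC(c2nccs2)=NC1(C)c1ccc(F)cc1`, gives 39 mL/min/kg
- compound 3, `COC(=O)C1=C(CN2CCC(O)CC2)NC(c2nccs2)=NC1(C)c1ccc(F)cc1`, gives 81 mL/min/kg

Compound 2 stands lowest of the three: both a 2.1-fold higher number from compound 2 to compound 3 (0.32 log units; beyond the scatter) and a 2.3-fold lower number from compound 1 to compound 2 (0.35 log units; beyond the scatter) lie beyond the scatter, whereas a 1.1-fold lower number from compound 1 to compound 3 (0.04 log units; within the scatter) does not, so compound 1 and compound 3 cannot be told apart here.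

Compound 4, `COC(=O)C1=C(COCC(F)(F)F)NC(c2nccs2)=NC1(C)c1ccc(F)cc1`, is still to be measured in this assay. Its change from compound 2 is 2,2,2-trifluoroethoxy in place of piperazin-1-yl on a saturated chain carbon bound to a double-bonded ring carbon. The two measured steps that bear on it are those that exchange the group at this same position, a 2.3-fold lower number from compound 1 to compound 2 (0.35 log units; beyond the scatter) and a 2.1-fold higher number from compound 2 to compound 3 (0.32 log units; beyond the scatter): each is modest in size, and each shows compound 2 with the lowest number of the pair. Among the measured compounds shown here, neither step involves a group without a ring or a group carrying fluorine, so the new group has no direct precedent among the three compounds, and the expectation rests on the observation that every measured departure from piperazin-1-yl at this position has given a higher number. Compound 4 is therefore expected to return a number above compound 2, estimated at 75 mL/min/kg with a range from 35 mL/min/kg to 160 mL/min/kg. That estimate amounts to a 1.9-fold higher number from compound 2 to compound 4 (0.28 log units; within the scatter), a modest step beyond the scatter in the direction of faster removal.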

Compound 4, clearance: 81 mL/min/kg
Compound 4: the middle estimate sits 1.1-fold (0.03 log units) below what was measured; measured number inside the range.
By their numbers in this assay, from the lowest: compound 2; then compounds 3, 4 and 1 (each within the scatter of the next).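

In this assay, among the compounds shown here, the change to 2,2,2-trifluoroethoxy gives a 2.1-fold higher number from compound 2 to compound 4 (0.32 log units; beyond the scatter), and this is the first departure from piperazin-1-yl at this position to a group with no ring and with fluorine. The same group gives no change at the digits printed from compound 3 to compound 4 (within the scatter) and a 1.1-fold lower number from compound 1 to compound 4 (0.04 log units; within the scatter), so compounds 1, 3 and 4 cannot be told apart despite their different groups, and a ring on this saturated chain carbon is not needed to reach that level. Among the four compounds, only compound 2 stands apart beyond the scatter from all the others, and nothing available here accounts for that separation.

The compounds shown leave open whether the lower number goes with the second ring nitrogen of piperazin-1-yl, which a morpholinyl group or a methyl group on that nitrogen would begin to test, and whether an open-chain amine such as dimethylamino would behave like piperazin-1-yl or like the other groups. They also leave open whether the fluorine atoms play any part in the number for compound 4, which plain ethoxy at the same position would address.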